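Ortho substituent swap on a urea: from acetyl to fluoro

A few compounds are considered here, and "the series" means these few. Any claim that something is new, unique, unknown or untested is made for them only; others in the source may bear on it.

Compound 1 `C[C@@H](NC(=O)Nc1ccccc1C(C)(C)C)c1ccccc1` and compound 2 `CC(=O)c1ccccc1NC(=O)N[C@H](C)c1ccccc1` share a urea core. In an ADME assay on the whole organism with Oryza sativa as the target, tested at 1 uM (a higher number here means a weaker effect of the compound at the concentration tested, a lower number a stronger effect), compound 1 gives 95% and compound 2 gives 95%; the step of no change at the digits printed from compound 1 to compound 2 (within the scatter) shows the two level within the scatter. Compound 3 `C[C@@H](NC(=O)Nc1ccccc1F)c1ccccc1` differs from compound 2 in one place: fluoro in place of acetyl on an aromatic carbon. For the measured compounds named here, only the step from compound 1 to compound 2 bears on this change, and it was flat, so the account expects no step beyond the scatter in this assay, namely a number 2 percentage points lower from compound 2 to compound 3 (within the scatter). Compound 3 is therefore estimated at 93%, within 80% to 100%.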

Compound 3, a percentage reported as activity, at one concentration (the size of the read-out at that concentration, not a potency): 95%
Estimate against measurement, compound 3: 2 percentage points below; low and high end bracket the measured number.
By their numbers in this assay, from the lowest: compounds 1, 2 and 3 (each within the scatter of the next).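

In this assay, fluoro in place of acetyl on the aromatic carbon gives no change at the digits printed from compound 2 to compound 3 (within the scatter), and fluoro in place of tert-butyl gives no change at the digits printed from compound 1 to compound 3 (within the scatter). The flatness seen between tert-butyl and acetyl thus extends to a substituent of a single heavy atom, so all three groups at this position read level within the scatter. No independent measurement bears on why the read-out stays flat here. On these data alone, whether an amine or a carboxylic acid at this position would move the number beyond the scatter remains open.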